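The source may report more compounds than this note shows. Statements on the series, on what has been measured and on what is new or still open speak of the compounds shown alone.

Two measured compounds share one core and differ only in the acid-bearing chain on the aromatic carbon. Compound 1 `O=C(O)CCc1ccccc1-c1cccc(-c2ccccc2OCc2ccccc2)c1` carries a 2-carboxyethyl chain, and in an assay on HEK293 cells for binding affinity to prostaglandin E2 receptor EP2 subtype (Homo sapiens) (a higher number here means a weaker inhibitor, a lower number a stronger inhibitor), compound 1 gives 3700 nM. Compound 2 `O=C(O)/C=C/c1ccccc1-c1cccc(-c2ccccc2OCc2ccccc2)c1` carries a 2-carboxyethenyl chain instead, and in this assay compound 2 gives 830 nM. Among the compounds with values here, that single change gave a 4.5-fold lower number from compound 1 to compound 2 (0.65 log units; beyond the scatter), so compound 2 stands with the lowest of the two numbers seen so far, with compound 1 as its only neighbour.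

Compound 3 `CC(Cc1ccccc1-c1cccc(-c2ccccc2OCc2ccccc2)c1)C(=O)O` is the next step from compound 2: 2-carboxypropyl in place of 2-carboxyethenyl on an aromatic carbon. Within the data shown here, only one measured step bears on this change, and it is the step from compound 1 to compound 2, which runs the other way, from a chain with no double bond outside the aromatic rings to one with a double bond, and lowered the number by a 4.5-fold lower number from compound 1 to compound 2 (0.65 log units; beyond the scatter). Compound 3 returns to a chain with no such double bond, with one extra carbon, so a rise back toward the number of compound 1 is expected. For compound 3 the estimate in this assay is 3000 nM, with a range from 1000 nM to 9000 nM. That estimate means an expected step of a 3.6-fold higher number from compound 2 to compound 3 (0.56 log units; beyond the scatter).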

Compound 3, inhibition constant: 3600 nM
Beside the measured number, compound 3's estimate is 1.2-fold (0.08 log units) below it; the measured number falls inside the stated range.
By their numbers in this assay, from the lowest: compound 2; then compounds 3 and 1 (each within the scatter of the next).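

In this assay, replacing the 2-carboxyethenyl chain with the 2-carboxypropyl chain gives a 4.3-fold higher number from compound 2 to compound 3 (0.64 log units; beyond the scatter), so the lower number of compound 2 does not survive in a chain with one double bond outside the aromatic rings rather than two. Adding a methyl to the saturated chain carbon bound to the carbonyl carbon gives a 1.0-fold lower number from compound 1 to compound 3 (0.01 log units; within the scatter), so at this position the extra carbon leaves the number of the 2-carboxyethyl chain in place, and among the three chains only the 2-carboxyethenyl chain stands apart. Nothing available explains why the chain with the extra double bond stands apart from the two others.

As far as these compounds go, the effects of the double bond and the methyl have so far been seen only separately, so what a 2-carboxyethenyl chain carrying a methyl would give remains open. Also open, from the compounds shown here alone, is how a longer chain ending in a carboxylic acid, or an amide or a tetrazole in place of that acid, would compare at this position.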